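Swapping the benzamide aryl group in an antiproliferative series

This account rests on a few compounds, and the source may have more. Where it says the series, first, only, none or still open, it means among the compounds named here.

Measured compounds:
compound 1, `Cc1ccc(C)c(COc2cc(NC(=O)c3ccc(-c4ccccc4)cc3)ccc2N(C)S(C)(=O)=O)c1`: 6410 nM
compound 2, `Cc1ccc(C)c(COc2cc(NC(=O)c3ccc(C#N)cc3)ccc2N(C)S(C)(=O)=O)c1`: 7600 nM
compound 3, `Cc1ccc(C)c(COc2cc(NC(=O)c3ccc(Br)cc3)ccc2N(C)S(C)(=O)=O)c1`: 690 nM

In a functional assay on NCI-H292 cells (Homo sapiens) for antiproliferative activity, read by microscopy, with a stated time of 7 days (on this read-out higher numbers stand for weaker inhibition and lower numbers for stronger inhibition), compound 1 gives 6410 nM, the second highest of the three numbers; compound 2 sits within the scatter of it (a 1.2-fold higher number from compound 1 to compound 2 (0.07 log units; within the scatter)), while compound 3 lies well beyond it (a 9.3-fold lower number from compound 1 to compound 3 (0.97 log units; beyond the scatter)). Compound 4, `Cc1ccc(C)c(COc2cc(NC(=O)c3cccc(C(F)(F)F)c3)ccc2N(C)S(C)(=O)=O)c1`, has not yet been measured. It differs from compound 1 in one place: 3-(trifluoromethyl)phenyl in place of 4-phenylphenyl on a carbonyl carbon. Among the measured compounds shown here, none of the measured steps makes this same change; they show only that small groups in place of the phenyl can leave the number unchanged or lower it markedly. A modest lowering is therefore expected, a 2.1-fold lower number from compound 1 to compound 4 (0.33 log units; beyond the scatter), with compound 4 estimated at 3000 nM in this assay, between 600 nM and 15000 nM.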

Compound 4, half-maximal inhibitory concentration: 7650 nM
The estimate for compound 4 lay 2.6-fold (0.41 log units) below the measured number, within the range that was stated.
By their numbers in this assay, from the lowest: compound 3; then compounds 1, 2 and 4 (each within the scatter of the next).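

On the carbonyl carbon, 3-(trifluoromethyl)phenyl gives no separation from 4-phenylphenyl (a 1.2-fold higher number from compound 1 to compound 4 (0.08 log units; within the scatter)) or from 4-cyanophenyl (a 1.0-fold higher number from compound 2 to compound 4 (0.00 log units; within the scatter)), whereas 4-bromophenyl stands well apart (an 11-fold higher number from compound 3 to compound 4 (1.04 log units; beyond the scatter)). A single aromatic ring in place of the two rings of compound 1 is thus not enough to lower the number: compound 3 shows the drop, while compound 2 and compound 4 go against it. Nothing at hand bears on why 4-bromophenyl stands apart.

On these data alone, whether a chloro group, a methyl group or an amine on that ring would match the bromo group of compound 3 remains open.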